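Cycloheptyl in place of cyclohexyl on the carbonyl carbon

This account rests on a few compounds, and the source may have more. Where it says the series, first, only, none or still open, it means among the compounds named here.

Of the compounds shown here, three on the shared core have been measured in an in vivo functional assay on the whole organism (MDA-MB-435 cells, Homo sapiens) for antiproliferative activity; a lower number here means a stronger inhibitor, a higher number a weaker inhibitor. Compound 1 `CO[C@@H](C(=O)NC1CC[C@@H](OC(=O)c2ccccc2)CNC1=O)[C@H](O)[C@@H](O)[C@H](O)/C=C/C(C)(C)C` gives 370 nM, compound 2 `CCCCCc1ccc(C(=O)O[C@@H]2CCC(NC(=O)[C@H](OC)[C@H](O)[C@@H](O)[C@H](O)/C=C/C(C)(C)C)C(=O)NC2)cc1` gives 20 nM, and compound 3 `CO[C@@H](C(=O)NC1CC[C@@H](OC(=O)C2CCCCC2)CNC1=O)[C@H](O)[C@@H](O)[C@H](O)/C=C/C(C)(C)C` gives 4 nM, the lowest number of the three.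

Compound 4 `CO[C@@H](C(=O)NC1CC[C@@H](OC(=O)C2CCCCCC2)CNC1=O)[C@H](O)[C@@H](O)[C@H](O)/C=C/C(C)(C)C` has cycloheptyl in place of cyclohexyl on a carbonyl carbon.

The measured steps all concern the group at this same place. The largest, a 93-fold lower number from compound 1 to compound 3 (1.97 log units; beyond the scatter), is cyclohexyl in place of phenyl. The next, a 19-fold lower number from compound 1 to compound 2 (1.27 log units; beyond the scatter), adds pentyl to the aromatic ring, and a 5.0-fold lower number from compound 2 to compound 3 (0.70 log units; beyond the scatter) is cyclohexyl in place of 4-pentylphenyl. Each of these involves an aromatic group, so none exchanges one non-aromatic carbon ring for another, and they bear on this change only indirectly.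

With compound 3 at 4 nM as the anchor, no step beyond the scatter is expected, and any drift is expected to be slightly upward. The expected step is a 1.5-fold higher number from compound 3 to compound 4 (0.18 log units; within the scatter). For compound 4 the estimated value is 6 nM, with an expected range of 2 nM to 25 nM.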

Compound 4, half-maximal inhibitory concentration: 20 nM
Beside the measured number, compound 4's estimate is 3.3-fold (0.52 log units) below it; low and high end bracket the measured number.
By their numbers in this assay, from the lowest: compound 3; then compounds 2 and 4 (each within the scatter of the next); then compound 1.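

In this assay, among these compounds, the non-aromatic carbon ring on this carbonyl carbon is not interchangeable: a 5.0-fold higher number from compound 3 to compound 4 (0.70 log units; beyond the scatter) is the first step here that changes ring size alone, and compound 3 keeps the lowest number of the series. The gain over the unsubstituted phenyl group largely survives in the seven-membered ring, with a 19-fold lower number from compound 1 to compound 4 (1.27 log units; beyond the scatter) and, against the 4-pentylphenyl group, no change at the digits printed from compound 2 to compound 4 (within the scatter). No measurement on hand explains why the six-membered ring gives the lower number.

With only two non-aromatic rings shown, the compounds cannot tell whether cyclohexyl marks an optimum, and cyclopentyl or cyclobutyl would test the smaller side. A piperidine ring or an open chain such as hexyl at this place would show whether a carbon ring is needed at all.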